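The source may report more compounds than this note shows. Statements on the series, on what has been measured and on what is new or still open speak of the compounds shown alone.

Among the compounds with values here, compound 1 (`CS(=O)(=O)c1ccc(-c2nc3ccccn3c2Sc2ccccc2)cc1`) gives 23200 nM in a functional assay on A549 cells (Homo sapiens) for inhibition, read by MTT assay, with a stated time of 48 h (on this read-out higher numbers stand for weaker inhibition and lower numbers for stronger inhibition), and holds the lower of the two numbers so far. Within the data shown here, its one measured neighbour, compound 2 (`CCc1ccc(-c2nc3ccccn3c2Sc2ccccc2)cc1`), gives 56200 nM in this assay with the rest of the structure unchanged. That pair, with ethyl in place of methylsulfonyl on an aromatic carbon, shows a 2.4-fold higher number from compound 1 to compound 2 (0.38 log units; beyond the scatter) and counts as a modest step.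

Next in line is compound 3 (`CSc1ccc(-c2nc3ccccn3c2Sc2ccccc2)cc1`), which carries methylsulfanyl in place of methylsulfonyl at the same place, para to a large group: methylsulfanyl in place of methylsulfonyl on an aromatic carbon (a single change on an aromatic carbon). Among the measured compounds shown here, only one measured step bears on this change, and it also removes methylsulfonyl. For the measured compounds named here, a single pair is thin support, and no compound yet tests methylsulfanyl directly. Going by the step to compound 2 of a 2.4-fold higher number from compound 1 to compound 2 (0.38 log units; beyond the scatter) in this assay, a move toward a higher number is expected, of similar or somewhat smaller size. The expected step is a 1.9-fold higher number from compound 1 to compound 3 (0.29 log units; within the scatter) on this reasoning. For compound 3 the estimate is 45000 nM with an expected range from 20000 nM to 100000 nM for now.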

Compound 3, half-maximal inhibitory concentration: 13600 nM
The estimate for compound 3 lay 3.3-fold (0.52 log units) above the measured number; measured number outside the range, below it.
By their numbers in this assay, from the lowest: compounds 3 and 1 (each within the scatter of the next); then compound 2.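

At this place on the aromatic carbon, para to a large group, methylsulfanyl and methylsulfonyl are not separated in this assay, with a 1.7-fold lower number from compound 1 to compound 3 (0.23 log units; within the scatter) as the step between them. Methylsulfanyl in place of ethyl gives a 4.1-fold lower number from compound 2 to compound 3 (0.62 log units; beyond the scatter), the largest step among the three compounds, so compound 2 now lies beyond the scatter from both sulfur-bearing compounds rather than from compound 1 alone. Among these compounds, then, the two oxygen atoms can leave the group without a step beyond the scatter, whereas the two steps to ethyl both go beyond it, and the earlier single pair could not show this split.

As far as these compounds go, three groups at a single place remain a narrow base, and it is open whether an amine, a carboxylic acid, a methoxy group or a longer sulfur-linked chain at this position would stay with the two sulfur-bearing groups or move away from them. From the compounds shown here alone, it is also open whether the same order of groups would hold with another substituent on the phenylsulfanyl part of the shared core. No measurement at hand accounts for the differences among these three numbers.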